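Second methoxy on compound 2: expected effect

A few compounds are considered here, and "the series" means these few. Any claim that something is new, unique, unknown or untested is made for them only; others in the source may bear on it.

Values in a functional assay on A549 cells (Homo sapiens) for inhibition, read by MTT assay, with a stated time of 48 h (a higher number here means a weaker inhibitor, a lower number a stronger inhibitor), so far:
- compound 1 `Oc1cccc(C(c2c[nH]c3ccc(Br)cc23)c2c[nH]c3ccc(Br)cc23)c1` gives 8000 nM
- compound 2 `COc1ccc(C(c2c[nH]c3ccc(Br)cc23)c2c[nH]c3ccc(Br)cc23)cc1` gives 10000 nM

Compound 2 at 10000 nM lies within the scatter of compound 1, so neither stands apart on these numbers. Compound 3 `COc1ccc(C(c2c[nH]c3ccc(Br)cc23)c2c[nH]c3ccc(Br)cc23)cc1OC` differs from compound 2 by one change, methoxy in place of hydrogen on an aromatic carbon, ortho to a methoxy group, which turns 4-methoxyphenyl to 3,4-dimethoxyphenyl methoxy in place of hydrogen on an aromatic carbon and leaves the rest untouched. Among the measured compounds shown here, the single measured step involving that phenyl group is a 1.3-fold higher number from compound 1 to compound 2 (0.10 log units; within the scatter) and it stays small. For the measured compounds named here, no measurement yet isolates a second methoxy, so no shift beyond the scatter is expected in this assay for this change. The expected step is a 1.1-fold lower number from compound 2 to compound 3 (0.05 log units; within the scatter) and nothing larger is anticipated. Compound 3 is estimated at 9000 nM with 4000 nM to 20000 nM as the expected working range.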

Compound 3, half-maximal inhibitory concentration: 12000 nM
The estimate for compound 3 lay 1.3-fold (0.12 log units) below the measured number; low and high end bracket the measured number.
By their numbers in this assay, from the lowest: compounds 1, 2 and 3 (each within the scatter of the next).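

In this assay, methoxy in place of hydrogen on the aromatic carbon ortho to a methoxy group gives a 1.2-fold higher number from compound 2 to compound 3 (0.08 log units; within the scatter) and so brings no shift that these numbers can separate from the scatter. Taking 4-methoxyphenyl to 3,4-dimethoxyphenyl therefore adds nothing readable at this position, and the change from 3-hydroxyphenyl to 3,4-dimethoxyphenyl, a 1.5-fold higher number from compound 1 to compound 3 (0.18 log units; within the scatter) also stays within the scatter, so all three phenyl patterns here read alike. No supporting data are available to account for this flat result.

Still open, from the compounds shown here alone, is whether an amine or a carboxylic acid on this phenyl ring would move the number beyond the scatter. Also open, going by these compounds, is whether any change to the shared core, rather than to the phenyl group, would do so.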